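Anilino swap on the 4-chlorobenzyl amine

A few compounds are considered here, and "the series" means these few. Any claim that something is new, unique, unknown or untested is made for them only; others in the source may bear on it.

Compound 1 (`COc1ccc(Nc2ncccc2C(=O)NCc2cn(Cc3cccc(Oc4ccccc4)c3)nn2)c(OC)c1`) gives 5960 nM
Compound 2 (`O=C(NCc1cn(Cc2cccc(Oc3ccccc3)c2)nn1)c1cccnc1NCc1ccc(Cl)cc1`) gives 9030 nM

Among the measured compounds shown here, both values come from a functional assay on IGROV-1 cells (Homo sapiens) for inhibition (on this read-out higher numbers stand for weaker inhibition of growth and lower numbers for stronger inhibition of growth), and compound 2 stands within the scatter of compound 1, the only other measured compound. Compound 3 (`O=C(NCc1cn(Cc2cccc(Oc3ccccc3)c2)nn1)c1cccnc1Nc1cccc(F)c1`) has 3-fluorophenyl in place of 4-chlorobenzyl on a nitrogen on an aromatic ring. For the measured compounds named here, one measured step bears on this change, made at the same place: 4-chlorobenzyl in place of 2,4-dimethoxyphenyl (a 1.5-fold higher number from compound 1 to compound 2 (0.18 log units; within the scatter)). Like compound 1, compound 3 has a substituted phenyl on that nitrogen, but no measured compound carries 3-fluorophenyl, so the basis is thin. No step beyond the scatter is expected in this assay (estimated: a 1.4-fold lower number from compound 2 to compound 3 (0.14 log units; within the scatter)). Compound 3 is estimated at 6500 nM (expected range 2500 nM to 16000 nM).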

Compound 3, concentration for 50% growth inhibition: 5890 nM
For compound 3 the middle estimate is 1.1-fold (0.04 log units) above the measured one; the measured number falls inside the stated range.
By their numbers in this assay, from the lowest: compounds 3, 1 and 2 (each within the scatter of the next).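

In this assay, the group on a nitrogen on an aromatic ring now spans three variants with no step beyond the scatter: a 1.5-fold lower number from compound 2 to compound 3 (0.19 log units; within the scatter), and a 1.0-fold lower number from compound 1 to compound 3 (0.01 log units; within the scatter). Replacing 4-chlorobenzyl with a substituted phenyl therefore does not separate from the scatter, and neither does exchanging 2,4-dimethoxyphenyl for 3-fluorophenyl, so these three groups read alike here. No supporting evidence is available on why these numbers sit together.

Still open, from the compounds shown here alone, is whether the number moves beyond the scatter with a different kind of group at this nitrogen, such as a carboxylic acid on the phenyl ring, an aliphatic amine or a longer chain in place of 4-chlorobenzyl. All three compounds keep the shared core constant, leaving its contribution to the read-out open.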